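Swapping a Sulfamide for an Acyl Sulfamide on the Chain

The compounds below may be only part of what the source reports. "The series", "measured", "known", "first", "only" and "open" are said of these compounds alone.

Measured so far:
compound 1, `O=C(CCCCCCC(=O)Nc1cccc(-c2ccccc2)c1)NO`: 9 nM
compound 2, `CN(C)S(=O)(=O)NCCCCCC(=O)Nc1cccc(-c2ccccc2)c1`: > 10000 nM

Both were tested in an assay for inhibition of protein deacetylase HDAC6 (Homo sapiens), read by fluorescence; a higher number here means a weaker inhibitor, a lower number a stronger inhibitor. Compound 1 gives 9 nM. Compound 2 gives only a limit of the assay, > 10000 nM, so no exact number is known for it. That is where compound 2 stands: at the weak end of what was measured, sitting on the limit described by the limit of > 10000 nM in this assay, at which 1 of the 2 values shown sits. Going by the values given here, the one measured step, an at least 1100-fold higher number from compound 1 to compound 2 (3.04 log units; beyond the scatter), shows that exchanging the hydroxycarbamoyl group for the dimethylsulfamoyl amine cost a great deal of inhibition.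

Compound 3, `NS(=O)(=O)NC(=O)CCCCCC(=O)Nc1cccc(-c2ccccc2)c1`, has not yet been measured. It differs from compound 2 by sulfamoylcarbamoyl in place of (dimethylsulfamoyl)amino on a saturated chain carbon, five bonds along the chain from a carbonyl carbon. No measured step covers this exchange directly; the only step shown concerns the loss of the hydroxycarbamoyl group. Starting from a limit, any step can only be guessed: the new group might restore some activity or leave it at the limit. Compound 3 is therefore expected to give about 5000 nM, within roughly 800 nM to 30000 nM, meaning an estimated step of an at least 2.0-fold lower number from compound 2 to compound 3 (0.30 log units; that floor lies within the scatter).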

Compound 3, half-maximal inhibitory concentration: > 10000 nM
Compound 3 was reported as a limit; the forecaster's own chance of this, stated with the estimate: 45%; middle value at least 2.0-fold (0.30 log units) from the limit.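

Compound 3 brings a carbonyl onto the chain in the sulfamoylcarbamoyl group, yet in this assay compound 3 gives > 10000 nM, which is a limit of the assay and not a number. Placing sulfamoylcarbamoyl on a saturated chain carbon, five bonds along the chain from a carbonyl carbon, in place of (hydroxycarbamoyl)methyl gives an at least 1100-fold higher number from compound 1 to compound 3 (3.04 log units; beyond the scatter), so a second replacement for that group now stands far from the 1 compound's level, and the large loss no longer rests on the (dimethylsulfamoyl)amino group alone. The step between the two replacement groups themselves cannot be read, because both values are limits: the limit of > 10000 nM in this assay, at which 2 of the 3 values shown sit.

As far as these compounds go, how far each of the two compounds lies past that limit stays unknown, so neither replacement group can be ranked against the other. The compounds shown also leave open whether a carboxylic acid or a primary amide at this place, or a longer chain carrying the sulfamoylcarbamoyl group, would give a measurable number in this assay.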